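This account rests on a few compounds, and the source may have more. Where it says the series, first, only, none or still open, it means among the compounds named here.

Measured compounds:
Compound 1 `COc1ccc(-c2cc(/C=C/C(=O)c3ccc(N)cc3)[nH]n2)cc1` gives 100% in a functional assay on HCT-15 cells (Homo sapiens) for cytotoxicity, read by sulforhodamine B assay, with a stated time of 48 h, tested at 0.1 uM; a higher number here means a weaker effect of the compound at the concentration tested, a lower number a stronger effect.
Compound 2 `COc1cc(-c2cc(/C=C/C(=O)c3ccc(N)cc3)[nH]n2)cc(OC)c1OC` gives 94% in this assay.
Compound 3 `COc1ccc(C(=O)/C=C/c2cc(-c3cc(OC)c(OC)c(OC)c3)n[nH]2)cc1` gives 100% in this assay.

Compound 2 carries three methoxy groups on one ring and an amino group on the other; its number in this assay sits within the usual scatter of both compound 1 and compound 3, so the three measured compounds cannot be told apart at this concentration. Among the compounds with values here, the single measured step, a number 6 percentage points higher from compound 2 to compound 3 (within the scatter), swaps the amino group for methoxy and stays within the scatter.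

Compound 4 `COc1ccc(-c2cc(/C=C/C(=O)c3ccc(N)cc3)[nH]n2)cc1OC` arises from compound 2 by hydrogen in place of methoxy on an aromatic carbon. Within the data shown here, no measured step removes a methoxy group, but compound 1, with one methoxy group on that ring, and compound 2, with three, show numbers within the scatter of each other. Compound 4, with two, is therefore expected to land between them, with a number 3 percentage points higher from compound 2 to compound 4 (within the scatter) expected to stay within the scatter. The estimate for compound 4 in this assay is 97%, ranging from 86% to 100%.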

Compound 4, a percentage reported as activity, at one concentration (the size of the read-out at that concentration, not a potency): 95%
Beside the measured number, compound 4's estimate is 2 percentage points above it; measured number inside the range.
By their numbers in this assay, from the lowest: compounds 2, 4, 1 and 3 (each within the scatter of the next).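

In this assay this position now has a direct reading: hydrogen in place of methoxy on an aromatic carbon, ortho to a methoxy group and meta to a large group, gives a number 1 percentage points higher from compound 2 to compound 4 (within the scatter) and so does not separate the two compounds. Methoxy in place of hydrogen on an aromatic carbon gives a number 5 percentage points lower from compound 1 to compound 4 (within the scatter) as well, so neither single methoxy change on this ring leaves the scatter at this concentration. No measurement at hand offers an explanation for these small steps.

As far as these compounds go, whether a hydroxyl group, a fluorine atom or a longer chain such as ethoxy at this position would give a step beyond the scatter remains open. Also open, from the compounds shown here alone, is whether compound 1, compound 2 and compound 4 would separate at another concentration.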